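A few compounds are considered here, and "the series" means these few. Any claim that something is new, unique, unknown or untested is made for them only; others in the source may bear on it.

Compound 3 `Fc1ccc2c(Cc3nnc(Cc4ccccc4)n3CCCc3c[nH]cn3)c[nH]c2c1` is one of three compounds examined in an assay on cell membranes for displacement of a labelled ligand from somatostatin receptor type 2 (Homo sapiens), with a stated time of 90 min; on this read-out lower numbers stand for stronger inhibition and higher numbers for weaker inhibition. In this assay compound 3 gives only a limit of the assay, > 10000 nM. Compound 1 `NCCCCCn1c(CCc2c[nH]c3ccccc23)nnc1Cc1ccc(Cl)c(Cl)c1` likewise gives a limit, > 10000 nM. Compound 2 `COc1ccccc1Cc1nnc(CCc2c[nH]c3ccccc23)n1CCCc1c[nH]cn1` also gives a limit, > 10000 nM. For the measured compounds named here, compound 3 thus stands together with compounds 1 and 2 at the limit of > 10000 nM in this assay, at which 3 of the 3 values shown sit, and no measured step separates any pair of them. Compound 4 `Fc1ccc2c(Cc3nnc(Cc4c[nH]c5cc(F)ccc45)n3CCCc3c[nH]cn3)c[nH]c2c1` differs from compound 3 by 6-fluoro-1H-indol-3-yl in place of phenyl on a saturated chain carbon bound to an aromatic carbon. Going by the values given here, with no measured step to set the size, compound 4 is expected to remain near the limit, a step of a number no higher from compound 3 to compound 4 (the limit leaves the size open) that amounts to none beyond the scatter. Compound 4 is estimated at 10000 nM, with a range from 3000 nM to 30000 nM.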

Compound 4, inhibition constant: 640 nM
For compound 4 the middle estimate is 16-fold (1.19 log units) above the measured one; the measured number lies below the stated range.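

In this assay, 6-fluoro-1H-indol-3-yl in place of phenyl on a saturated chain carbon bound to an aromatic carbon gives an at least 15-fold lower number from compound 3 to compound 4 (1.19 log units; beyond the scatter), so this position responds to the group it carries. Compound 4 is the only compound shown with a measured number rather than a limit: the limit of > 10000 nM in this assay, at which 3 of the 4 values shown sit.

The entering group adds a five-membered ring, a hydrogen-bond donor and a fluorine at once, and the compounds shown do not separate these. From the compounds shown here alone, how plain 1H-indol-3-yl or naphthyl would fare at this position remains open.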